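A few compounds are considered here, and "the series" means these few. Any claim that something is new, unique, unknown or untested is made for them only; others in the source may bear on it.

Measured in an ADME assay on MT4 cells (Homo sapiens) for cytotoxicity, read by MTT assay, with a stated time of 96 h (a higher number here means that more compound is tolerated, a lower number that less compound is tolerated), are:
Compound 1 `NS(=O)(=O)c1ccc(N2N=C(c3ccc(OCc4ccccc4)cc3)CC2c2ccccc2)cc1` gives > 100000 nM as a limit of the assay
Compound 2 `NS(=O)(=O)c1ccc(N2N=C(c3ccc(OCc4ccccc4)cc3)CC2c2ccc(Cl)cc2)cc1` gives 70000 nM
Compound 3 `Cc1cccc(C2CC(c3ccc(OCc4ccccc4)cc3)=NN2c2ccc(S(N)(=O)=O)cc2)c1` gives 44000 nM

Compound 3 stands level with compound 2 within the scatter (a 1.6-fold lower number from compound 2 to compound 3 (0.20 log units; within the scatter)), and that step swapped 4-chlorophenyl for 3-methylphenyl. Compound 4 `NS(=O)(=O)c1ccc(N2N=C(c3ccc(OCc4ccccc4)cc3)CC2c2cccc(Cl)c2)cc1` carries chloro in place of methyl on an aromatic carbon, which reads 3-methylphenyl to 3-chlorophenyl. Two measured steps put these groups in place of hydrogen, chloro in one (an at least 1.4-fold lower number from compound 1 to compound 2 (0.15 log units; that floor lies within the scatter)) and methyl in the other (an at least 2.2-fold lower number from compound 1 to compound 3 (0.35 log units; beyond the scatter)). Both are floors, and only the methyl step clears the scatter. No step beyond the scatter is therefore expected in this assay, and the estimated change is small (a 1.3-fold higher number from compound 3 to compound 4 (0.10 log units; within the scatter)). Compound 4 is expected at 55000 nM with an estimated range (27000 nM to 100000 nM).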

Compound 4, half-maximal cytotoxic concentration: 36000 nM
Beside the measured number, compound 4's estimate is 1.5-fold (0.18 log units) above it; low and high end bracket the measured number.
By their numbers in this assay, from the lowest: compounds 4, 3 and 2 (each within the scatter of the next). At a limit, above all of these: compound 1.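

On the aromatic carbon meta to a large group, chloro and methyl cannot be told apart in this assay (a 1.2-fold lower number from compound 3 to compound 4 (0.09 log units; within the scatter)). Shifting the chloro from 4-chlorophenyl to 3-chlorophenyl also stays within the scatter (a 1.9-fold lower number from compound 2 to compound 4 (0.29 log units; within the scatter)). Against hydrogen, chloro at this place clears the scatter (an at least 2.7-fold lower number from compound 1 to compound 4 (0.44 log units; beyond the scatter)), which the 4-chlorophenyl step did not, but this figure is only a floor set by a limit: the limit of > 100000 nM in this assay, at which 1 of the 4 values shown sits.

On these data alone, the true size of the step from hydrogen remains open. So does whether an amine or a methoxy group on this carbon would read apart from chloro and methyl.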